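The compounds below may be only part of what the source reports. "The series", "measured", "known", "first", "only" and "open" are said of these compounds alone.

Measured so far:
compound 1, `COc1cc(Cl)nc(NC(=S)NC(=O)c2c(-c3ccc(Cl)cc3Cl)noc2C)n1`, 62.2%
compound 2, `COc1cc(OC)n2s/c(=N\C(=O)c3c(-c4ccc(Cl)cc4Cl)noc3C)nc2n1`, 85.3%
compound 3, `COc1cc(OC)nc(NC(=S)NC(=O)c2c(-c3ccc(Cl)cc3Cl)noc2C)n1`, 65.9%

All three were tested in a functional assay on the whole organism for inhibition, with Digitaria ciliaris as the target, with a stated time of 72 h, tested at 100 mg/L; a lower number here means less inhibition of growth, a higher number more inhibition of growth at the concentration tested. Compound 2 gives the highest number of the three, and its distance to compound 3 and to compound 1 lies beyond the scatter in each case. Compound 3 and compound 1 share a core, and compound 1 differs from compound 3 by chloro in place of methoxy on an aromatic carbon; this step gives a number 3.7 percentage points lower from compound 3 to compound 1 (within the scatter). The cores of compound 2 and compound 3 differ as well, but that difference is not broken down here.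

Compound 4, `COc1cc(Cl)nc2n/c(=N/C(=O)c3c(-c4ccc(Cl)cc4Cl)noc3C)sn12`, is not yet measured. It differs from compound 2 by chloro in place of methoxy on an aromatic carbon. This is the same kind of change as from compound 3 to compound 1, though the surroundings differ: in compound 4 the carbon is meta to a fused ring and para to a fused ring, whereas in compound 1 it is meta to a large group. Because a number 3.7 percentage points lower from compound 3 to compound 1 (within the scatter) stayed within the scatter, a similarly small step a number 2.3 percentage points lower from compound 2 to compound 4 (within the scatter) is expected here. Compound 4 is therefore estimated at 83%, between 70% and 93%.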

Compound 4, percent growth inhibition at one concentration: 72.8%
The estimate for compound 4 lay 10.2 percentage points above the measured number; the range from low to high includes it.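

In this assay the swap of methoxy for chloro on the core of compound 2 gives a number 12.5 percentage points lower from compound 2 to compound 4 (beyond the scatter) and so counts as a real, if modest, loss of growth inhibition on this core. Taken alone, that step could suggest that the swap costs more here than on the core of compound 1, but the comparison of the two cores does not support this. As far as these two pairs go, the change carries from one core to the other with no clear difference in size, although two pairs cannot prove that the size is the same or explain the result: the same change on two cores in this assay, a number 3.7 percentage points lower (within the scatter) from compound 3 to compound 1 and a number 12.5 percentage points lower (beyond the scatter) from compound 2 to compound 4, 8.8 percentage points apart, within the scatter of two such steps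

The compounds shown leave open how other groups would behave on this aromatic carbon, such as an amine, a nitrile or a longer chain like butoxy. They also leave open whether the change would act in the same way on a third core or on another plant species.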